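Amide aryl variation on a shared flavonol core

A few compounds are considered here, and "the series" means these few. Any claim that something is new, unique, unknown or untested is made for them only; others in the source may bear on it.

The series holds the core of compound 2 `O=C(Nc1cccc(-c2oc3cc(-c4ccc(F)cc4)ccc3c(=O)c2O)c1)c1ccc(Cl)cc1` constant and varies the aryl group on the amide carbonyl. Among the compounds with values here, in a functional assay on HeLa cells (Homo sapiens) for antiproliferative activity, read by CCK-8 assay, with a stated time of 72 h (on this read-out lower numbers stand for stronger inhibition and higher numbers for weaker inhibition), compound 2 gives 3670 nM, the lowest number of the three measured so far. Compound 1 `O=C(Nc1cccc(-c2oc3cc(-c4ccc(F)cc4)ccc3c(=O)c2O)c1)c1ccc(F)cc1` gives 5350 nM, and the step of a 1.5-fold lower number from compound 1 to compound 2 (0.16 log units; within the scatter) does not separate them. Compound 3 `COc1ccccc1C(=O)Nc1cccc(-c2oc3cc(-c4ccc(F)cc4)ccc3c(=O)c2O)c1` gives 14100 nM; the steps of a 2.6-fold higher number from compound 1 to compound 3 (0.42 log units; beyond the scatter) and a 3.8-fold higher number from compound 2 to compound 3 (0.58 log units; beyond the scatter) show that a 2-methoxyphenyl on the carbonyl carbon costs a modest amount of activity against either halogenated aryl.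

Compound 4 `Cc1cc(C)cc(C(=O)Nc2cccc(-c3oc4cc(-c5ccc(F)cc5)ccc4c(=O)c3O)c2)c1` is the next member to be measured. Its change from compound 2 is 3,5-dimethylphenyl in place of 4-chlorophenyl on a carbonyl carbon. Within the data shown here, no measured step covers a dimethyl pattern on this aryl group. The step from compound 1 to compound 2 shows that exchanging one aryl substituent for another of similar kind leaves the number within the scatter, while the steps to compound 3 show that a more distinct aryl change raises it modestly. The expected outcome for compound 4 therefore lies between these cases: a small rise, a 1.4-fold higher number from compound 2 to compound 4 (0.13 log units; within the scatter), that may not clear the scatter. On this basis compound 4 is estimated at 5000 nM in this assay, with a range from 2000 nM to 14000 nM.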

Compound 4, half-maximal inhibitory concentration: 5540 nM
Compound 4: the middle estimate sits 1.1-fold (0.04 log units) below what was measured, within the range that was stated.
By their numbers in this assay, from the lowest: compounds 2, 1 and 4 (each within the scatter of the next); then compound 3.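

In this assay, within the data shown here, 3,5-dimethylphenyl on the carbonyl carbon is the first aryl group here that carries neither a halogen nor an oxygen, and a 1.5-fold higher number from compound 2 to compound 4 (0.18 log units; within the scatter) and a 1.0-fold higher number from compound 1 to compound 4 (0.02 log units; within the scatter) both leave it inside the scatter of the halogenated aryl groups. Compound 3 therefore stands apart from all three other compounds, with a 2.5-fold lower number from compound 3 to compound 4 (0.41 log units; beyond the scatter) adding a third modest step to the two already seen against the halogenated aryl groups, so a halogen on this aryl group is not needed to reach the numbers of compound 1 and compound 2. No measurement at hand explains why these aryl groups fall together or why 2-methoxyphenyl differs.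

From the compounds shown here alone, it remains open whether the higher number of compound 3 is specific to the methoxy group or would also appear with an amine or a carboxylic acid on this aryl group. The compounds shown also do not tell how the number would respond to a single methyl group on the aryl group, or to a longer chain in its place on the carbonyl carbon.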